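This account rests on a few compounds, and the source may have more. Where it says the series, first, only, none or still open, it means among the compounds named here.

Compound 1, `C=C[C@@](C)(/C=C/c1ccc(OC)cc1)CCC=C(C)C`, is the starting point. In an ADME assay on BJ cells (Homo sapiens) for cytotoxicity, with a stated time of 72 h (a higher number here means that more compound is needed for the effect, a lower number that less compound is needed), compound 1 gives > 36600 nM, and this is a limit of the assay rather than a number. Two related compounds were measured alongside it. Compound 2, `C=C[C@@](C)(/C=C/c1ccc(O)cc1)CC/C=C(\C)CO`, also reaches only a limit: in this assay compound 2 gives > 36600 nM. Compound 3, `C=C[C@@](C)(/C=C/c1ccc(O)c(/C=C/C(=O)NCc2ccc(C(F)(F)F)cc2)c1)CCC=C(C)C`, ends the same way, since in this assay compound 3 gives > 36600 nM, again a limit. Compound 1 therefore stands exactly where every measured value here stands, at the limit of > 36600 nM in this assay, at which 3 of the 3 values shown sit, and no difference among the three can be read from these numbers.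

Compound 4, `C=C[C@@](C)(/C=C/c1ccc(-c2ccc(F)cc2)cc1)CCC=C(C)C`, has not yet been measured. It differs from compound 1 in one place: 4-fluorophenyl in place of methoxy on an aromatic carbon.

There is no measured pair differing in a single place, so the size of this change cannot be taken from a shown step. Because all three measured compounds sit at the limit of > 36600 nM in this assay, at which 3 of the 3 values shown sit, the expectation for compound 4 in this assay is no step beyond the usual scatter in either direction. The step that this estimate implies is a step that the limit leaves unreadable from compound 1 to compound 4. Compound 4 is expected to give about 40000 nM, with a range from 15000 nM to 100000 nM, most likely reported again only as a limit.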

Compound 4, half-maximal effective concentration: > 36600 nM
Compound 4 was reported as a limit; the forecaster's own chance of this, stated with the estimate: 70%; the middle value lies beyond the limit too.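

Compound 1 and compound 4 both end at a limit of the assay rather than a number, so no step can be read for 4-fluorophenyl in place of methoxy: the limit of > 36600 nM in this assay, at which 4 of the 4 values shown sit. The compounds shown leave open how much of any of them is needed for the effect in this assay, and whether any single change alters that amount.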